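This account rests on a few compounds, and the source may have more. Where it says the series, first, only, none or still open, it means among the compounds named here.

Working notes on the series in a functional assay on ECa-109 cells (Homo sapiens) for inhibition, read by MTT assay, with a stated time of 72 h; on this read-out lower numbers stand for stronger inhibition and higher numbers for weaker inhibition. For the measured compounds named here, compound 2 `Cc1ccc(Nc2nc(SCc3cn(CC(=O)NC(=O)Nc4ccccn4)nn3)nc(-c3ccc(Cl)cc3)c2C#N)cc1` gives 13100 nM, the larger of the two numbers measured so far, though its gap to compound 1 is within the scatter. Compound 1 `Cc1ccc(Nc2nc(SCc3cn(CC(=O)NC(=O)Nc4ccccn4)nn3)nc(-c3ccc(C(C)C)cc3)c2C#N)cc1` gives 6700 nM, and the step of a 2.0-fold higher number from compound 1 to compound 2 (0.29 log units; within the scatter) stays within the scatter. Compound 3 `Cc1ccc(Nc2nc(SCc3cn(CC(=O)NC(=O)Nc4ccccn4)nn3)nc(-c3ccccc3)c2C#N)cc1` differs from compound 2 by hydrogen in place of chloro on an aromatic carbon, read one bond further out as 4-chlorophenyl to phenyl. Going by the values given here, the only measured step at this position was the one just named, and it was within the scatter, so no step beyond the scatter is expected in this assay. For compound 3 the value is estimated at 15000 nM, with a range from 6000 nM to 40000 nM. The expected step is then a 1.1-fold higher number from compound 2 to compound 3 (0.06 log units; within the scatter).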

Compound 3, half-maximal inhibitory concentration: 24600 nM
For compound 3 the middle estimate is 1.6-fold (0.21 log units) below the measured one; the measured number falls inside the stated range.
By their numbers in this assay, from the lowest: compounds 1, 2 and 3 (each within the scatter of the next, the first and the last beyond it).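

In this assay, hydrogen in place of chloro gives a step (a 1.9-fold higher number from compound 2 to compound 3 (0.27 log units; within the scatter)) that does not separate the 4-chlorophenyl and phenyl compounds. Hydrogen in place of isopropyl on the same aromatic carbon gives the first step at this position beyond the scatter (a 3.7-fold higher number from compound 1 to compound 3 (0.56 log units; beyond the scatter)), though only a modest one. No measured evidence accounts for either step. Still open, from the compounds shown here alone, is how a methoxy group, an amine or a longer alkyl chain at this position would compare with isopropyl in compound 1.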